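Moving the Chlorine Around the Phenyl Ring of Compound 2

The source may report more compounds than this note shows. Statements on the series, on what has been measured and on what is new or still open speak of the compounds shown alone.

Measured so far:
compound 1, `Clc1ccc(-c2cc(-c3ccoc3)cc(-c3cccs3)n2)cc1`, 50000 nM;
compound 2, `Clc1cccc(-c2cc(-c3ccc(Cl)o3)cc(-c3cccs3)n2)c1`, 15500 nM.

In a functional assay on HCT-15 cells (Homo sapiens) for cytotoxicity, in the presence of a further agent that is not named here (a higher number here means a weaker inhibitor, a lower number a stronger inhibitor), compound 2 holds the lowest of the two numbers; compound 1 gives a higher number, a gap beyond the scatter. Compound 3, `Clc1ccc(-c2cc(-c3ccc(Cl)o3)cc(-c3cccs3)n2)cc1`, differs from compound 2 by 4-chlorophenyl in place of 3-chlorophenyl on an aromatic carbon. Going by the values given here, no measured pair shows this change by itself, so only a small step, if any, is expected from compound 2 to compound 3 in this assay, more likely toward a higher number given compound 1 at 50000 nM. For compound 3 the estimate is 25000 nM, with a range of 10000 nM to 60000 nM, meaning an expected step of a 1.6-fold higher number from compound 2 to compound 3 (0.21 log units; within the scatter).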

Compound 3, half-maximal inhibitory concentration: 14200 nM
Compound 3: middle estimate off by 1.8-fold (0.25 log units), on the high side, within the range that was stated.
By their numbers in this assay, from the lowest: compounds 3 and 2 (each within the scatter of the next); then compound 1.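

In this assay the switch from 3-chlorophenyl to 4-chlorophenyl gives a 1.1-fold lower number from compound 2 to compound 3 (0.04 log units; within the scatter) and so shows no readable preference between these two chlorine placements at this position. Going by these compounds alone, with 4-chlorophenyl held fixed, 5-chlorofuran-2-yl in place of furan-3-yl gives a 3.5-fold lower number from compound 1 to compound 3 (0.55 log units; beyond the scatter) as the first single-place step beyond the scatter, so the furan position moves the number where the chlorine shift on the phenyl ring does not. Nothing available explains either result. Going by these compounds, it remains open how an amine or a methoxy group on the phenyl ring would fare, and whether a carboxylic acid in place of the thiophen-2-yl group would move the number.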